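The source may report more compounds than this note shows. Statements on the series, on what has been measured and on what is new or still open speak of the compounds shown alone.

Compound 1 `COc1cc(C2CC(c3cc4ccccc4o3)=NN2C(=O)Nc2cccc(O)c2)ccc1O` gives 24000000 nM
Compound 2 `COc1cc(C2CC(c3cc4ccccc4o3)=NN2C(=O)Nc2ccc(C)cc2)ccc1O` gives 44000000 nM

Within the data shown here, these are the only two numbers so far in a functional assay on microsomes from liver (Rattus norvegicus, strain Wistar) for inhibition, with a stated time of 15 min (on this read-out lower numbers stand for stronger inhibition and higher numbers for weaker inhibition), and they lie within the scatter of each other, so compound 2 cannot be ranked against its one measured neighbour. Compound 3 `COc1cc(C2CC(c3cc4ccccc4o3)=NN2C(=O)Nc2ccc(Br)cc2)ccc1O` carries bromo in place of methyl on an aromatic carbon, para to a large group, and otherwise matches compound 2 (bromo in place of methyl on an aromatic carbon). Among the measured compounds shown here, the one measured step, a 1.8-fold higher number from compound 1 to compound 2 (0.26 log units; within the scatter) and within the scatter, put 4-methylphenyl in place of 3-hydroxyphenyl on an amide-type nitrogen. For the measured compounds named here, it touches the same aromatic group, but no measured compound carries bromo. No step beyond the scatter is therefore expected in this assay and the estimated change is small, a 1.1-fold lower number from compound 2 to compound 3 (0.04 log units; within the scatter) in size. For compound 3 the estimated value is 40000000 nM (expected range 16000000 nM to 90000000 nM).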

Compound 3, half-maximal inhibitory concentration: 115000000 nM
Compound 3: middle estimate off by 2.9-fold (0.46 log units), on the low side, outside the stated range (above it).
By their numbers in this assay, from the lowest: compounds 1 and 2 (each within the scatter of the next); then compound 3.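

In this assay, among these compounds, the change from methyl to bromo, on an aromatic carbon para to a large group, gives the first step here that lies beyond the scatter (a 2.6-fold higher number from compound 2 to compound 3 (0.42 log units; beyond the scatter)), so this position is not indifferent to what sits on it, and bromo gives weaker inhibition than methyl. Compound 3 also separates from the 3-hydroxyphenyl compound (a 4.8-fold higher number from compound 1 to compound 3 (0.68 log units; beyond the scatter)), which makes it the weakest inhibitor of the three on this read-out. Nothing shown accounts for the difference between bromo and methyl.

The compounds shown leave open how a chloro group, a methoxy group, an amine or a carboxylic acid would read at this same position. They also leave open whether bromo would give a similar step elsewhere on this ring.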